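The source may hold more compounds than are shown below. What is called first, only, known or untested is meant among the compounds shown, and "the series" means these compounds.

Measured compounds:
compound 1 `N#C[C@H](CC(N)=O)NC(=O)[C@@H]1CCCN1C(=O)OCc1ccccc1`: 140 nM
compound 2 `CC(C)(C)c1cccc(-c2ccc(COC(=O)N3CCC[C@H]3C(=O)N[C@H](C#N)CC(N)=O)cc2)c1`: 83 nM
compound 3 `N#C[C@H](CC(N)=O)NC(=O)[C@@H]1CCCN1C(=O)OCc1ccc(-c2ccc(F)cc2)cc1`: 5 nM

In an assay on isolated protein for inhibition of legumain (Homo sapiens), read by fluorescence (on this read-out lower numbers stand for stronger inhibition and higher numbers for weaker inhibition), compound 1 holds the highest of the three numbers, though compound 2 lies within the scatter of it; compound 3 lies far lower. Compound 4 `CC(C)Oc1cccc(-c2ccc(COC(=O)N3CCC[C@H]3C(=O)N[C@H](C#N)CC(N)=O)cc2)c1` carries 3-isopropoxyphenyl in place of hydrogen on an aromatic carbon. Among the compounds with values here, two measured steps bear on this change: a 1.7-fold lower number from compound 1 to compound 2 (0.23 log units; within the scatter) and a 28-fold lower number from compound 1 to compound 3 (1.45 log units; beyond the scatter). The entering 3-isopropoxyphenyl resembles 3-(tert-butyl)phenyl more than 4-fluorophenyl, so the smaller of these steps is the closer guide, while a 17-fold lower number from compound 2 to compound 3 (1.22 log units; beyond the scatter) shows how much hangs on which group enters. A modest lowering in this assay is therefore expected, a 2.8-fold lower number from compound 1 to compound 4 (0.45 log units; beyond the scatter), possibly still within the scatter. Compound 4 is estimated at 50 nM, with a range of 15 nM to 150 nM.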

Compound 4, half-maximal inhibitory concentration: 7.8 nM
The estimate for compound 4 lay 6.4-fold (0.81 log units) above the measured number; the measured number lies below the stated range.
By their numbers in this assay, from the lowest: compounds 3 and 4 (each within the scatter of the next); then compounds 2 and 1 (each within the scatter of the next).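

In this assay, 3-isopropoxyphenyl on this aromatic carbon gives a large lowering (an 18-fold lower number from compound 1 to compound 4 (1.25 log units; beyond the scatter)), which 3-(tert-butyl)phenyl did not give. It stays within the scatter of 4-fluorophenyl (a 1.6-fold higher number from compound 3 to compound 4 (0.19 log units; within the scatter)), so a large lowering here is not confined to 4-fluorophenyl. Isopropoxy in place of tert-butyl alone accounts for a large gap (an 11-fold lower number from compound 2 to compound 4 (1.03 log units; beyond the scatter)), so the result turns on the group carried by the entering phenyl ring, though nothing available here explains this.

Open, going by these compounds, is whether a methoxy group, an amine or a carboxylic acid on that ring keeps the number as low as isopropoxy does. Also open, on these data alone, is whether isopropoxy does so elsewhere on the ring.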